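Chloroacetyl ester in place of hydroxyethyl ether on a chalcone

The source may hold more compounds than are shown below. What is called first, only, known or untested is meant among the compounds shown, and "the series" means these compounds.

Among the measured compounds shown here, in a functional assay on K562 cells (Homo sapiens) for cytotoxicity, read by MTT assay (on this read-out higher numbers stand for weaker inhibition and lower numbers for stronger inhibition), compound 3 `COc1ccc(/C=C/C(=O)c2ccc(OC)c3c2OC(C)(C)C=C3)cc1OCCO` gives 8750 nM, the only number among the three values shown. Compound 1 `COc1ccc(/C=C/C(=O)c2ccc(OC)c3c2OC(C)(C)C=C3)cc1OCC=C(C)C` reaches only the limit > 10000 nM in this assay. Compound 2 `C=CCOc1cc(/C=C/C(=O)c2ccc(OC)c3c2OC(C)(C)C=C3)ccc1OC` likewise reaches only the limit > 10000 nM. The steps of an at least 1.1-fold lower number from compound 1 to compound 3 (0.05 log units; that floor lies within the scatter) and an at least 1.1-fold lower number from compound 2 to compound 3 (0.05 log units; that floor lies within the scatter) sit at a floor that lies within the scatter, because both of the partner values sit at the limit of > 10000 nM in this assay, at which 2 of the 3 values shown sit. Compound 4 `COc1ccc(/C=C/C(=O)c2ccc(OC)c3c2OC(C)(C)C=C3)cc1OC(=O)CCl` differs from compound 3 by (chloromethyl)carbonyl in place of 2-hydroxyethyl on an oxygen on an aromatic ring. For the measured compounds named here, no measured step touches a (chloromethyl)carbonyl group; the measured steps alter only what hangs on that aromatic oxygen and stay within scatter, so the expected step is a 1.1-fold lower number from compound 3 to compound 4 (0.04 log units; within the scatter). Compound 4 is therefore estimated at 8000 nM, with a range from 3000 nM to 20000 nM.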

Compound 4, half-maximal inhibitory concentration: 400 nM
Compound 4: middle estimate off by 20-fold (1.30 log units), on the high side; measured number below the stated range.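

In this assay, (chloromethyl)carbonyl in place of 2-hydroxyethyl on the aromatic oxygen gives a 22-fold lower number from compound 3 to compound 4 (1.34 log units; beyond the scatter), a step beyond the scatter that no change among the three ethers showed. Against the other two ethers, the steps are an at least 25-fold lower number from compound 2 to compound 4 (1.39 log units; beyond the scatter) and an at least 25-fold lower number from compound 1 to compound 4 (1.39 log units; beyond the scatter). These two are floors because their starting values are limits: the limit of > 10000 nM in this assay, at which 2 of the 4 values shown sit.

Going by these compounds, whether the step depends on the ester link or on the chlorine stays open. A plain acetyl group on the same oxygen would separate the two.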